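A few compounds are considered here, and "the series" means these few. Any claim that something is new, unique, unknown or untested is made for them only; others in the source may bear on it.

Measured so far:
Compound 1, `CC(C)n1cnc2ncnc(N)c21`. In a functional assay on CHO cells for antagonist activity at adenosine receptor A2b (Homo sapiens) (a higher number here means a weaker inhibitor, a lower number a stronger inhibitor), compound 1 gives > 30000 nM, a limit of the assay rather than a number.
Compound 2, `Nc1ncnc2ncn(CCCO)c12`. In this assay compound 2 gives > 30000 nM, likewise a limit and not a number.

Because both values are limits, the step from compound 1 to compound 2, a step that the two limits leave unreadable from compound 1 to compound 2, cannot be sized. Going by the values given here, the only evidence on record is the limit of > 30000 nM in this assay, at which 2 of the 2 values shown sit, so compound 2 stands at the limit with no measured number on either side of it.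

Compound 3, `CC(O)Cn1cnc2ncnc(N)c21`, differs from compound 2 by 1-hydroxyethyl in place of 2-hydroxyethyl on a saturated chain carbon bound to an aromatic nitrogen. Among the compounds with values here, no measured step bears directly on this rearrangement, and the one step available is unreadable. With no shown reason to leave the limit, compound 3 is expected to remain there, estimated at 50000 nM with a range from 20000 nM to 300000 nM. The estimated step from compound 2 to compound 3, a step that the limit leaves unreadable from compound 2 to compound 3, is therefore expected to be nothing beyond the scatter.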

Compound 3, inhibition constant: > 30000 nM
Compound 3: a limit, no number (the forecaster's own chance of this, stated with the estimate: 85%); the middle value is on the limit's open side.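

In this assay compound 3 gives > 30000 nM, a limit and not a number. Going by these compounds alone, no step among compound 1, compound 2 and compound 3 can be read. Whether any of these chains on the aromatic nitrogen gives a measurable inhibition stays open: the limit of > 30000 nM in this assay, at which 3 of the 3 values shown sit.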